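This account rests on a few compounds, and the source may have more. Where it says the series, first, only, none or still open, it means among the compounds named here.

Measured in a functional assay on HCT-116 cells (Homo sapiens) for antiproliferative activity, read by MTT assay, with a stated time of 72 h; a lower number here means a stronger inhibitor, a higher number a weaker inhibitor:
- compound 1 `CC(C)(C)c1ccc(OCCCON2C(N)=NC(N)=NC23CCSCC3)cc1`: 1 nM
- compound 2 `NC1=NC2(CCSCC2)N(OCCCOc2ccc(Br)cc2)C(N)=N1`: 20 nM
- compound 3 `NC1=NC2(CCOCC2)N(OCCCOc2cccc(Cl)c2Cl)C(N)=N1`: 5 nM

Compound 3 sits in the middle of these three numbers, with a higher number for compound 2 and a lower one for compound 1.

Compound 4 `NC1=NC2(CCOCC2)N(OCCCOc2ccc(Cl)cc2Cl)C(N)=N1` keeps everything in compound 3 except one group, with 2,4-dichlorophenyl in place of 2,3-dichlorophenyl on an oxygen on a saturated carbon. The two compounds have the same atoms, joined differently.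

Among the compounds with values here, only one measured step offers any guide. a 20-fold higher number from compound 1 to compound 2 (1.30 log units; beyond the scatter) is large and shows that a swap on an aromatic carbon can shift the number a long way in this assay. That step exchanges two different groups, however, and it belongs to the core of compound 1, not that of compound 3. Within the data shown here, no measured pair shows a chlorine changing place, so the direction stays open, and no step beyond the scatter is expected.

The estimated change is a 1.2-fold higher number from compound 3 to compound 4 (0.08 log units; within the scatter).

For compound 4 the estimate is 6 nM, with an expected range from 1.5 nM to 25 nM.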

Compound 4, half-maximal inhibitory concentration: 880 nM
Beside the measured number, compound 4's estimate is 150-fold (2.17 log units) below it; measured number outside the range, above it.
By their numbers in this assay, from the lowest: compound 1; then compound 3; then compound 2; then compound 4.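

In this assay, the earlier step exchanged two different groups, whereas here the groups on the aromatic ring stay the same and only the position of one chlorine changes. This change, 2,4-dichlorophenyl in place of 2,3-dichlorophenyl, gives a 180-fold higher number from compound 3 to compound 4 (2.25 log units; beyond the scatter), so the arrangement of the two chlorines matters at this position, not merely their presence. The data shown offer no measurement that accounts for this large shift.

On these data alone, it remains open whether the same exchange would have a similar effect on the core of compound 1, since this pair covers only the core of compound 3. The compounds shown also do not reveal how a phenyl group carrying a single chlorine or a methoxy group would compare with these two dichlorophenyl groups.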